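A few compounds are considered here, and "the series" means these few. Any claim that something is new, unique, unknown or untested is made for them only; others in the source may bear on it.

Of the compounds shown here, two built on a shared core have been measured so far. Compound 1 `O=C1CC(c2ccc(F)cc2)Nc2c(Br)cc(Br)cc21` carries a fluoro group on its pendant aromatic ring. In a functional assay on MCF7 cells (Homo sapiens) for inhibition, read by sulforhodamine B assay, with a stated time of 48 h (on this read-out higher numbers stand for weaker inhibition of growth and lower numbers for stronger inhibition of growth), compound 1 gives only a limit of the assay, < 100 nM. Compound 2 `O=C1CC(c2ccc(Br)cc2)Nc2c(Br)cc(Br)cc21` has a bromo group in that place instead, and in this assay compound 2 gives 151 nM. Among the values shown for this assay, compound 2 holds the only number; the other value is a limit, as the limit of < 100 nM in this assay, at which 1 of the 2 values shown sits, records. The step of an at least 1.5-fold higher number from compound 1 to compound 2 (0.17 log units; that floor lies within the scatter) therefore cannot be sized closely.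

Compound 3 `O=C1CC(c2ccc([N+](=O)[O-])cc2)Nc2c(Br)cc(Br)cc21` differs from compound 2 in one place: nitro in place of bromo on an aromatic carbon. Going by the values given here, only one measured step, an at least 1.5-fold higher number from compound 1 to compound 2 (0.17 log units; that floor lies within the scatter), touches that same place, and it exchanged fluoro for bromo rather than bringing in nitro, so it sets no clear direction for the change in this assay. The number for compound 3 in this assay is therefore expected to lie near that of compound 2, with the step of a 1.3-fold higher number from compound 2 to compound 3 (0.12 log units; within the scatter) staying within the scatter. Compound 3 is estimated at 200 nM, within a range from 60 nM to 700 nM.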

Compound 3, concentration for 50% growth inhibition: < 100 nM
Compound 3 ended at the assay's limit; the forecaster's own chance of this, stated with the estimate: 20%; middle value at least 2.0-fold (0.30 log units) away from the limit.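

In this assay, putting nitro in place of bromo gives an at least 1.5-fold lower number from compound 2 to compound 3 (0.17 log units; that floor lies within the scatter). This position therefore tolerates more than a single halogen atom: a group of three heavy atoms with two hydrogen-bond acceptors replaces one bromine, and the number does not rise, although the size of the step remains uncertain and its floor does not clear the usual scatter. The value for compound 3 is a limit of the assay, the step between compound 1 and compound 3 cannot be read, and fluoro and nitro therefore cannot be ranked against each other, with only compound 2 carrying an actual number: the limit of < 100 nM in this assay, at which 2 of the 3 values shown sit.

As far as these compounds go, how far compound 1 and compound 3 really lie from compound 2 remains open, and so does whether any change at this position moves the number by more than the scatter. It is also unknown how an amine, a carboxylic acid or a methoxy group on that same aromatic carbon would behave, so the three groups shown do not yet define a trend for this position.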